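The source may report more compounds than this note shows. Statements on the series, on what has been measured and on what is new or still open speak of the compounds shown alone.

Two members of the series have been run in a functional assay on MCF7 cells (Homo sapiens) for inhibition, read by MTT assay, with a stated time of 72 h; on this read-out higher numbers stand for weaker inhibition and lower numbers for stronger inhibition. Compound 1 `Cc1cc(Nc2cc(-c3ccccc3)[nH]n2)n2nc(SCc3ccc([N+](=O)[O-])cc3)nc2n1` gives 5060 nM and stands highest of the two numbers. Compound 2 `Cc1cc(Nc2ccn(Cc3nc(C)c4ccccc4n3)n2)n2nc(SCc3ccc(Br)cc3)nc2n1` gives 1430 nM, a lower number than compound 1, and the gap between them lies beyond the usual scatter. Compound 1 and compound 2 differ at several places at once, so no single change can be read from that pair.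

Compound 3 `Cc1cc(Nc2cc(-c3ccccc3)[nH]n2)n2ncnc2n1` has not been measured. Against compound 1 it shows one change: hydrogen in place of (4-nitrobenzyl)sulfanyl on an aromatic carbon. Going by the values given here, no measured pair separated by a single change exists in this set, so the size of this step has to be judged without a direct precedent. The expected step is a 3.0-fold higher number from compound 1 to compound 3 (0.47 log units; beyond the scatter), upward in number, and probably beyond the scatter rather than within it. For compound 3 the estimate in this assay is 15000 nM, with a range from 4000 nM to 60000 nM, and a limit rather than a number is a real possibility.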

Compound 3, half-maximal inhibitory concentration: > 50000 nM
Compound 3: a limit, no number; the forecaster's own chance of this, stated with the estimate: 25%; middle value at least 3.3-fold (0.52 log units) from the limit.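

Compound 3 gives > 50000 nM in this assay, which is a limit of the assay and not a number. Going by these compounds alone, replacing (4-nitrobenzyl)sulfanyl with hydrogen on this aromatic carbon, between two ring nitrogen atoms, gives an at least 9.8-fold higher number from compound 1 to compound 3 (0.99 log units; beyond the scatter); this is the first single-change step, and it shows that the substituent at this position matters for the read-out, which compounds 1 and 2 alone could not show. The step is a lower bound, so its full size stays unknown, and the reading is capped at the top of the assay range: the limit of > 50000 nM in this assay, at which 1 of the 3 values shown sits.

The compounds shown leave open which part of the (4-nitrobenzyl)sulfanyl group carries the step, and whether a plain benzylsulfanyl group, a short methylsulfanyl group or an amine on the same carbon would restore a measurable number in this assay. Compound 2 differs from compound 1 at several places, so it gives no separate reading of the nitro group or of any other part of that substituent.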